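The compounds below may be only part of what the source reports. "The series", "measured", "known", "first", "only" and "open" are said of these compounds alone.

Measured compounds:
compound 1, `COc1ccc(/C=N/c2c(C)n(C)n(-c3ccccc3)c2=O)cc1`: 186000000 nM
compound 2, `Cc1c(/N=C/c2ccccc2Cl)c(=O)n(-c2ccccc2)n1C`: 324000000 nM
compound 3, `COc1cccc(/C=N/c2c(C)n(C)n(-c3ccccc3)c2=O)c1`: 105000000 nM

In a functional assay on P388 cells (Mus musculus) for cytotoxicity, read by MTT assay, with a stated time of 72 h (a lower number here means a stronger inhibitor, a higher number a weaker inhibitor), compound 1 gives 186000000 nM, the second highest of the three numbers. Its nearest neighbour is compound 2, reached by a 1.7-fold higher number from compound 1 to compound 2 (0.24 log units; within the scatter), and its furthest is compound 3, reached by a 1.8-fold lower number from compound 1 to compound 3 (0.25 log units; within the scatter). For the measured compounds named here, the only step that leaves the scatter is a 3.1-fold lower number from compound 2 to compound 3 (0.49 log units; beyond the scatter).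

Compound 4, `Cc1c(/N=C/c2cccc(Cl)c2)c(=O)n(-c2ccccc2)n1C`, has not yet been measured in this assay. It differs from compound 1 as follows: 3-chlorophenyl in place of 4-methoxyphenyl on a carbon with a double bond to nitrogen. Going by the values given here, two measured steps bear on this change. Swapping methoxyphenyl for chlorophenyl, as from compound 1 to compound 2, stayed within the scatter, and moving a methoxy from the 4- to the 3-position, as from compound 1 to compound 3, also stayed within the scatter. The change to compound 4 combines both kinds of alteration, and neither alone moved the number beyond the scatter, so no step beyond the scatter is expected in this assay. The estimated step is a 1.1-fold higher number from compound 1 to compound 4 (0.03 log units; within the scatter). Compound 4 is therefore expected to give about 200000000 nM, in the range 90000000 nM to 450000000 nM.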

Compound 4, half-maximal inhibitory concentration: 550000000 nM
Estimate against measurement, compound 4: 2.8-fold (0.44 log units) below; measured number above the stated range.
By their numbers in this assay, from the lowest: compounds 3, 1, 2 and 4 (each within the scatter of the next, the first and the last beyond it).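

In this assay, the 3-chlorophenyl group gives the first step from compound 1 that leaves the scatter (a 3.0-fold higher number from compound 1 to compound 4 (0.47 log units; beyond the scatter)). The sharper contrast comes with chloro in place of methoxy on an aromatic carbon (a 5.2-fold higher number from compound 3 to compound 4 (0.72 log units; beyond the scatter)), the largest step among these compounds, although compound 2 goes against any general rule that chloro raises the number, since its step from compound 1 stayed within the scatter. The two chlorophenyl compounds cannot be told apart (a 1.7-fold higher number from compound 2 to compound 4 (0.23 log units; within the scatter)), so these data give no sign that the place of the chloro matters.

Nothing given here accounts for these steps.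
Going by these compounds, whether an amine, a carboxylic acid or a longer chain in place of these aryl groups would bring the number down remains open.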